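The compounds below may be only part of what the source reports. "The series", "measured", "known", "first", "only" and "open" are said of these compounds alone.

Three compounds of a shared core differ only in the group bound to an oxygen on an aromatic ring. Compound 1 `CCCCCCOc1cccc(O)c1C(=O)/C=C/c1ccc(O)cc1` carries a pentyl there. In a functional assay on NUGC-3 cells (Homo sapiens) for antiproliferative activity, read by sulforhodamine B assay (on this read-out lower numbers stand for stronger inhibition of growth and higher numbers for weaker inhibition of growth), compound 1 reaches only the limit > 30000 nM. Compound 2 `CC(C)=CCOc1cccc(O)c1C(=O)/C=C/c1ccc(O)cc1` carries a 2-methylprop-1-en-1-yl, and in this assay compound 2 also reaches only the limit > 30000 nM. Compound 3 `O=C(/C=C/c1ccc(O)cc1)c1c(O)cccc1OCc1ccccc1` carries a phenyl, and in this assay compound 3 likewise reaches only the limit > 30000 nM. Compound 3 therefore stands at the edge of what the measurement reports, sharing that position with the other two, as the limit of > 30000 nM in this assay, at which 3 of the 3 values shown sit, shows. The steps a step that the two limits leave unreadable from compound 1 to compound 2, a step that the two limits leave unreadable from compound 1 to compound 3 and a step that the two limits leave unreadable from compound 2 to compound 3 cannot be read in size.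

Compound 4 `O=C(/C=C/c1ccc(O)cc1)c1c(O)cccc1OCC1CCCC1` changes compound 3 by cyclopentyl in place of phenyl on a saturated chain carbon bound to an oxygen on an aromatic ring. The unreadable steps give no direction for this change, so the expected step that the limit leaves unreadable from compound 3 to compound 4 is one that most likely stays beyond the reporting limit. Compound 4 is expected in this assay to give about 45000 nM, within 15000 nM to 150000 nM, and most probably only a limit again.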

Compound 4, concentration for 50% growth inhibition: 2140 nM
Compound 4: the middle estimate sits 21-fold (1.32 log units) above what was measured; the measured number lies below the stated range.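

In this assay, putting cyclopentyl on the saturated chain carbon bound to an oxygen on an aromatic ring gives an at least 14-fold lower number from compound 3 to compound 4 (1.14 log units; beyond the scatter), and the same group also gives an at least 14-fold lower number from compound 2 to compound 4 (1.14 log units; beyond the scatter) and an at least 14-fold lower number from compound 1 to compound 4 (1.14 log units; beyond the scatter). The earlier compounds shown here could not show that this position responds to its group at all, since pentyl, 2-methylprop-1-en-1-yl and phenyl all left the read-out at a limit. Among the compounds shown, only the five-membered non-aromatic ring gives a number rather than a limit: the limit of > 30000 nM in this assay, at which 3 of the 4 values shown sit.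

The compounds shown leave open whether this activity depends on the size of that ring, as a cyclobutyl or cyclohexyl would tell. They also leave open whether an oxygen or an amine within the ring would keep it.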